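This account rests on a few compounds, and the source may have more. Where it says the series, first, only, none or still open, it means among the compounds named here.

Measured compounds:
compound 1 `C=C(Br)C(=O)Nc1cccc(-c2cn3c(-c4ccc(OC)cc4)csc3n2)c1` — 500 nM
compound 2 `C=C(Br)C(=O)Nc1cccc(-c2cn3c(-c4ccccc4)csc3n2)c1` — 2800 nM
compound 3 `C=C(Br)C(=O)Nc1cccc(-c2cn3nc(CCc4ccccc4)sc3n2)c1` — 4200 nM

In a functional assay on CCRF-CEM cells (Homo sapiens) for inhibition, read by cell counting, with a stated time of 3 days (on this read-out higher numbers stand for weaker inhibition and lower numbers for stronger inhibition), compound 3 stands highest of the three numbers; its gap to compound 2 lies within the scatter, while its gap to compound 1 lies beyond it. Compound 4 `C=C(Br)C(=O)Nc1cccc(-c2cn3nc(Cc4ccccc4)sc3n2)c1` differs from compound 3 by phenyl in place of benzyl on a saturated chain carbon bound to an aromatic carbon. Within the data shown here, the one measured step, a 5.6-fold higher number from compound 1 to compound 2 (0.75 log units; beyond the scatter), concerns a different part of the molecule and does not bear on this change; no measured pair varies the group on the saturated chain carbon bound to an aromatic carbon. The step of a 1.1-fold lower number from compound 3 to compound 4 (0.02 log units; within the scatter) is therefore expected to stay within the scatter, with no clear direction. Compound 4 is estimated at 4000 nM, in the range 1300 nM to 12000 nM.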

Compound 4, half-maximal inhibitory concentration: 4200 nM
For compound 4 the middle estimate is 1.1-fold (0.02 log units) below the measured one; measured number inside the range.
By their numbers in this assay, from the lowest: compound 1; then compounds 2, 3 and 4 (each within the scatter of the next).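

In this assay the swap of phenethyl to benzyl gives no change at the digits printed from compound 3 to compound 4 (within the scatter) and stays within the scatter. Among these compounds, this is the first pair that varies the group on the saturated chain carbon bound to an aromatic carbon, and at this position the read-out does not separate the two chains. No measurement on hand offers an explanation for this result.

Going by these compounds, both groups end in an unsubstituted phenyl, so the effect of a different end group at this position remains open. An amine, a carboxylic acid or a longer chain here could read differently.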